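Pyrazole carboxamide series: effect of the methoxy on the phenyl amide

This account rests on a few compounds, and the source may have more. Where it says the series, first, only, none or still open, it means among the compounds named here.

Measured so far:
compound 1 `COc1ccccc1C(=O)Nc1c[nH]nc1C(=O)N[C@H]1CC[C@H](OC)CC1` — 1500 nM
compound 2 `CO[C@H]1CC[C@H](NC(=O)c2n[nH]cc2NC(=O)c2ncoc2-c2ccccc2)CC1` — 28000 nM

Two compounds share the pyrazole carboxamide core carrying the methoxycyclohexyl amide. In an ADME assay on MRC5 cells (Homo sapiens) for inhibition, with a stated time of 72 h (on this read-out lower numbers stand for an effect already at smaller amounts and higher numbers for an effect only at larger amounts of compound), compound 1 gives 1500 nM, the lower of the two numbers. Compound 2, which carries a phenyl-oxazole amide instead of the 2-methoxyphenyl amide, gives 28000 nM in this assay, a higher number that lies beyond the usual scatter. For the measured compounds named here, no step between these two is computed, so only the two values themselves are noted here.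

Compound 3 `CO[C@H]1CC[C@H](NC(=O)c2n[nH]cc2NC(=O)c2ccccc2)CC1` has not yet been measured in this assay. It differs from compound 1 in one place: hydrogen in place of methoxy on an aromatic carbon. Cut one bond further out, the change reads 2-methoxyphenyl to phenyl.

Going by the values given here, no measured pair shows what this change does. Compound 1 gives the lowest number seen so far, and the single other data point, compound 2, gives a far higher one; on that basis a modest move toward a higher number is expected, with the estimated step of a 2.0-fold higher number from compound 1 to compound 3 (0.30 log units; within the scatter) from compound 1 to compound 3 in this assay. Compound 3 is therefore estimated at 3000 nM, within a range of 800 nM to 12000 nM.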

Compound 3, half-maximal effective concentration: 800 nM
Beside the measured number, compound 3's estimate is 3.8-fold (0.57 log units) above it; the range from low to high includes it.
By their numbers in this assay, from the lowest: compounds 3 and 1 (each within the scatter of the next); then compound 2.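

In this assay, hydrogen in place of methoxy on an aromatic carbon, ortho to a large group, gives a 1.9-fold lower number from compound 1 to compound 3 (0.27 log units; within the scatter), so this read-out does not separate the two compounds. The methoxy, with its 2 heavy atoms and 1 hydrogen-bond acceptor, is therefore not required at this position for a value in this range, and the unsubstituted phenyl amide serves as a simpler reference point for the series. Nothing available explains why the two values lie so close together.

Only methoxy and hydrogen are shown at this aromatic carbon, so it remains open whether the position tolerates substituents in general or whether a fluorine, a hydroxyl or an amine there would move the number beyond the scatter. The methoxycyclohexyl amide is also the same in all the compounds shown, which leaves open what a hydroxyl, a carboxylic acid or a longer chain in place of its methoxy would do in this assay.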